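The source may report more compounds than this note shows. Statements on the series, on what has been measured and on what is new or still open speak of the compounds shown alone.

Measured so far:
compound 1 `Nc1c(C(=O)NCc2ccc(F)cc2F)c(=O)n(O)c2ncc(CCCC3CCCCC3)cc12` — an ADME assay on HOS cells (Homo sapiens) for cytotoxicity, read by luminescence and ATP content, with a stated time of 48 h (a lower number here means that less compound is tolerated, a higher number that more compound is tolerated), 27400 nM
compound 2 `Nc1c(C(=O)NCc2ccc(F)cc2F)c(=O)n(O)c2ncc(CCCOCCO)cc12` — in this assay only a limit, > 250000 nM

Compound 2 stands at the limit of this assay, where one of the two recorded values sits (the limit of > 250000 nM in this assay, at which 1 of the 2 values shown sits); a number is known only for compound 1. Compound 3 `CC(C)NC(=O)CCc1cnc2c(c1)c(N)c(C(=O)NCc1ccc(F)cc1F)c(=O)n2O` differs from compound 2 by isopropylcarbamoyl in place of (2-hydroxyethoxy)methyl on a saturated chain carbon, two bonds along the chain from an aromatic carbon. Among the measured compounds shown here, the single measured step, an at least 9.1-fold higher number from compound 1 to compound 2 (0.96 log units; beyond the scatter), concerns another group and gives no direction beyond the scatter for the present change. Compound 3 is therefore expected to remain at the limit, estimated at 250000 nM (range 120000 nM to 400000 nM). The expected step is a number no higher from compound 2 to compound 3 (the limit leaves the size open).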

Compound 3, half-maximal cytotoxic concentration: > 250000 nM
Compound 3 was reported as a limit; the forecaster's own chance of this, stated with the estimate: 70%; the middle value sits exactly at the limit.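

In this assay, isopropylcarbamoyl in place of cyclohexylmethyl gives an at least 9.1-fold higher number from compound 1 to compound 3 (0.96 log units; beyond the scatter) and so shows that the higher tolerated level at this position is not tied to the hydroxyethoxy chain alone. Compound 2 and compound 3 both carry limits, and the step between them cannot be read. Two of the three compounds now rest at one limit: the limit of > 250000 nM in this assay, at which 2 of the 3 values shown sit.

From the compounds shown here alone, whether an amine or a carboxylic acid at the end of this chain would give a number inside the measurable range stays open. Any difference between the isopropylcarbamoyl and (2-hydroxyethoxy)methyl groups also stays open.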